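The source may hold more compounds than are shown below. What is called first, only, known or untested is meant among the compounds shown, and "the series" means these compounds.

Measured in a functional assay on A-431 cells (Homo sapiens) for inhibition, read by MTT assay, with a stated time of 72 h; on this read-out higher numbers stand for weaker inhibition and lower numbers for stronger inhibition:

- compound 1 `COc1ccc(-c2nnc(SCCCN3CCN(c4nc5ccccc5s4)CC3)o2)cc1`: 56200 nM
- compound 2 `O=[N+]([O-])c1ccc(-c2nnc(SCCCN3CCN(c4nc5ccccc5s4)CC3)o2)cc1`: 46500 nM
- compound 3 `Clc1ccc(-c2nnc(SCCCN3CCN(c4nc5ccccc5s4)CC3)o2)cc1`: 69200 nM

These three compounds share one core and differ only in a single group on an aromatic ring. Compound 3, at 69200 nM, cannot be told apart from the other two, as both comparisons lie within the scatter: a 1.2-fold higher number from compound 1 to compound 3 (0.09 log units; within the scatter) and a 1.5-fold higher number from compound 2 to compound 3 (0.17 log units; within the scatter).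

The next compound, compound 4 `Brc1ccc(-c2nnc(SCCCN3CCN(c4nc5ccccc5s4)CC3)o2)cc1`, changes that same group once more: bromo in place of chloro on an aromatic carbon. In words, this is bromo in place of chloro on an aromatic carbon, para to a large group.

Among the measured compounds shown here, no measured step makes this exact swap, so the closest guide is the set of changes already made at that place. Besides the two steps above, there is a 1.2-fold lower number from compound 1 to compound 2 (0.08 log units; within the scatter). Methoxy, nitro and chloro therefore gave no separation beyond the scatter in these three compounds, and a swap of chloro for bromo is not expected to do so either.

The expected change is small, a 1.2-fold lower number from compound 3 to compound 4 (0.06 log units; within the scatter), and no step beyond the scatter is expected. For compound 4 the estimated value is 60000 nM, with an expected range from 35000 nM to 100000 nM.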

Compound 4, half-maximal inhibitory concentration: 51600 nM
Compound 4: the middle estimate sits 1.2-fold (0.07 log units) above what was measured; the range from low to high includes it.
By their numbers in this assay, from the lowest: compounds 2, 4, 1 and 3 (each within the scatter of the next).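

Bromo in place of chloro, on the 4-chlorophenyl to 4-bromophenyl change, adds a fourth group at this place, and in this assay it again gives no separation: a 1.3-fold lower number from compound 3 to compound 4 (0.13 log units; within the scatter). The comparisons with the other two groups read the same way, with a 1.1-fold higher number from compound 2 to compound 4 (0.05 log units; within the scatter) and a 1.1-fold lower number from compound 1 to compound 4 (0.04 log units; within the scatter), so all four compounds now lie within the scatter of one another, and swapping one halogen for another at this place has proved no more telling than the earlier swaps among methoxy, nitro and chloro. There is no measured information here that explains why these four groups cannot be told apart in this cell assay.

Going by these compounds, what stays open is whether any group on this aromatic carbon can move the number beyond the scatter, which a plain hydrogen, an amine or a carboxylic acid at the same place would help to test. The compounds shown also all keep the rest of the shared core unchanged, so they say nothing about what a longer chain in that core would do.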